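The source may hold more compounds than are shown below. What is called first, only, known or untested is meant among the compounds shown, and "the series" means these compounds.

Measured so far: compound 1 `NC1CCC(Nc2nc(NCc3ccc(-c4ccccc4)cc3)c3ncn(C4CCCC4)c3n2)CC1` gives 530 nM; compound 2 `NC1CCC(Nc2nc(NCc3ccc(-c4ccccc4O)nc3)c3ncn(C4CCCC4)c3n2)CC1` gives 16 nM.

For the measured compounds named here, in a functional assay on K562 cells (Homo sapiens) for inhibition, with a stated time of 72 h (a higher number here means a weaker inhibitor, a lower number a stronger inhibitor), compound 1 stands at the higher of the two numbers, with compound 2 at a much lower value, though the two differ in several places and no single step links them. Compound 3 `Nc1ccccc1CNc1nc(NC2CCC(N)CC2)nc2c1ncn2C1CCCC1` differs from compound 1 by 2-aminophenyl in place of 4-phenylphenyl on a saturated chain carbon bound to a nitrogen on an aromatic ring. Going by the values given here, no measured step matches this change, so the step from compound 1 to compound 3 is expected to be small, a 1.8-fold lower number from compound 1 to compound 3 (0.25 log units; within the scatter), if anything a slight downward move that may not exceed the usual scatter. Compound 3 is estimated at 300 nM, ranging from 60 nM to 1500 nM.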

Compound 3, half-maximal inhibitory concentration: 4040 nM
The estimate for compound 3 lay 13-fold (1.13 log units) below the measured number; measured number above the stated range.
By their numbers in this assay, from the lowest: compound 2; then compound 1; then compound 3.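

In this assay, 2-aminophenyl in place of 4-phenylphenyl on a saturated chain carbon bound to a nitrogen on an aromatic ring gives a weaker inhibitor (a 7.6-fold higher number from compound 1 to compound 3 (0.88 log units; beyond the scatter)). This shows that the number responds to the group at this position, and that this single-ring group with its amine does not retain the activity of compound 1. No available evidence accounts for the step.

The compounds shown leave open whether the shift goes with losing the second aromatic ring or with gaining the amine. Plain phenyl at the same position would separate these two changes.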